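The source may report more compounds than this note shows. Statements on the series, on what has been measured and on what is new or still open speak of the compounds shown alone.

Of the compounds shown here, three have been measured in an ADME assay on MRC5 cells (Homo sapiens) for cytotoxicity, read by MTT assay, with a stated time of 72 h; a lower number here means a stronger inhibitor, a higher number a weaker inhibitor. Compound 1 `CC(C)(C)C1=CC(=O)C=C(NCCC(=O)O)C1=O` reaches only a limit of the assay and not a number, giving > 200000 nM. Compound 3 `CC(C)(C)C1=CC(=O)C=CC1=O` likewise stops at a limit, giving > 200000 nM. Among the compounds with values here, the one step that joins measured compounds, a step that the two limits leave unreadable from compound 1 to compound 3, cannot be read because of the limit of > 200000 nM in this assay, at which 2 of the 3 values shown sit. Within the data shown here, compound 2 `CC1=CCC[C@H]2[C@](C)(CC3=CC(=O)C=C(N[C@@H](CC(C)C)C(=O)O)C3=O)[C@@H](C)CC[C@]12C` gives 73400 nM, the only outright number among the three values shown. Compound 4 `CC1=CCC[C@H]2[C@](C)(CC3=CC(=O)C=C(NCC(=O)O)C3=O)[C@@H](C)CC[C@]12C` differs from compound 2 by hydrogen in place of isobutyl on a saturated chain carbon bound to an amine nitrogen and a carbonyl carbon. Among the measured compounds shown here, no measured step touches this kind of change, so nothing in the data says whether taking away the isobutyl should make the compound a stronger or a weaker inhibitor in this assay. The expectation is therefore a step of about zero, a 1.4-fold higher number from compound 2 to compound 4 (0.13 log units; within the scatter), with the spread left wide to cover either direction. Compound 4 is estimated at 100000 nM, between 40000 nM and 250000 nM, with a fair chance that the assay reports only a limit.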

Compound 4, half-maximal inhibitory concentration: 183000 nM
Compound 4: the middle estimate sits 1.8-fold (0.26 log units) below what was measured, and the stated range covers the measured number.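

In this assay, taking the isobutyl away from this saturated chain carbon bound to an amine nitrogen and a carbonyl carbon gives a 2.5-fold higher number from compound 2 to compound 4 (0.40 log units; beyond the scatter). The change therefore moves the compound toward weaker inhibition, and of this pair the compound that keeps the isobutyl is the stronger inhibitor. This is the first step in the series with a readable size, although it rests on one pair, since the only earlier step cannot be read: the limit of > 200000 nM in this assay, at which 2 of the 4 values shown sit.

On these data alone, it remains open how other groups on this carbon would behave, for example a single methyl, a longer chain, a benzyl group or an added amine. As far as these compounds go, it is also open whether the same change would give a similar step on the core of compound 1.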